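Trifluoromethyl to methyl on the aromatic carbon

The source may hold more compounds than are shown below. What is called first, only, known or untested is meant among the compounds shown, and "the series" means these compounds.

Measured in a functional assay on the whole organism with Mus musculus as the target (a higher number here means that more compound is needed for the effect, a lower number that less compound is needed), so far:
Compound 1 `CN1C(=O)CCC1(O)c1cccc(C(F)(F)F)c1` gives 51.6 mg/kg
Compound 2 `CCCN1C(=O)CCC1(O)c1cccc(C(F)(F)F)c1` gives 150 mg/kg

Compound 1 holds the lowest number of the two, so less of it is needed for the effect. Compound 3 `Cc1cccc(C2(O)CCC(=O)N2C)c1` is not yet measured. It departs from compound 1 by methyl in place of trifluoromethyl on an aromatic carbon. Among the compounds with values here, the only measured step, a 2.9-fold higher number from compound 1 to compound 2 (0.46 log units; beyond the scatter), is modest and lies at the amide-type nitrogen, not on the aromatic carbon. It therefore bears only indirectly, as a guide to size. Within the data shown here, no measured pair tests this aromatic group, so direction remains uncertain. A modest step towards a higher number in this assay is expected, and the estimate means a 1.7-fold higher number from compound 1 to compound 3 (0.24 log units; within the scatter). Compound 3 is estimated at 90 mg/kg, with an expected range from 35 mg/kg to 250 mg/kg.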

Compound 3, dose for half-maximal effect: 60.9 mg/kg
For compound 3 the middle estimate is 1.5-fold (0.17 log units) above the measured one, and the stated range covers the measured number.
By their numbers in this assay, from the lowest: compounds 1 and 3 (each within the scatter of the next); then compound 2.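

In this assay, the replacement on the aromatic carbon gives a 1.2-fold higher number from compound 1 to compound 3 (0.07 log units; within the scatter), so this pair does not separate trifluoromethyl from methyl at this position, although methyl carries fewer heavy atoms and no fluorine. Within the data shown here, this is the first measured pair that tests the position, and its step stays within the scatter, whereas a 2.9-fold higher number from compound 1 to compound 2 (0.46 log units; beyond the scatter), at the amide-type nitrogen, lies beyond it. Nothing on hand accounts for the similar numbers of this pair.

On these data alone, whether an amine, a methoxy group, a carboxylic acid or a chlorine atom on this aromatic carbon would also stay within the scatter of compound 1 remains open. Also open, as far as these compounds go, is whether methyl and trifluoromethyl stay equally close when the longer chain of compound 2 sits on the nitrogen.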